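A few compounds are considered here, and "the series" means these few. Any claim that something is new, unique, unknown or untested is made for them only; others in the source may bear on it.

For the measured compounds named here, in a physicochemical assay for permeability, using PAMPA (on this read-out lower numbers stand for lower permeability and higher numbers for higher permeability), compound 2 (`CC[C@@H]1C[C@H](CC)CN(CCCNC(=O)C2CCN(Cc3nc(-c4ccccc4C)oc3C)CC2)C1`) gives 1270 10^-6 cm/s, the only exact number in this small series. Compound 3 (`Cc1oc(-c2ccc(Cl)cc2)nc1CN1CCC(C(=O)NCCCN2C[C@H](C)C[C@H](C)C2)CC1`) gives > 635 10^-6 cm/s, which is a limit of the assay and not a number. Compound 1 (`Cc1cc(C)c(-c2nc(CN3CCC(C(=O)NCCCN4C[C@H](C)C[C@H](C)C4)CC3)c(C)o2)c(C)c1`) is recorded as "not determined" (no result reported). Compound 4 (`Cc1ccccc1-c1nc(CN2CCC(C(=O)NCCCN3[C@H](C)CCC[C@@H]3C)CC2)c(C)o1`) departs from compound 2 by 2,6-dimethylpiperidin-1-yl in place of 3,5-diethylpiperidin-1-yl on a saturated chain carbon, three bonds along the chain from an amide-type nitrogen, with 2,6-dimethylpiperidin-1-yl in place of 3,5-diethylpiperidin-1-yl on a saturated chain carbon, three bonds along the chain from an amide-type nitrogen. Going by the values given here, no measured pair shows such a change, so only a small downward move is expected in this assay, none beyond the scatter. The expected step is a 1.4-fold lower number from compound 2 to compound 4 (0.15 log units; within the scatter). For compound 4 the estimated value is 900 10^-6 cm/s, with an expected range from 350 10^-6 cm/s to 1800 10^-6 cm/s.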

Compound 4, apparent permeability: 55.4 10^-6 cm/s
Compound 4: middle estimate off by 16-fold (1.21 log units), on the high side; the measured number lies below the stated range.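

In this assay, the group on a saturated chain carbon, three bonds along the chain from an amide-type nitrogen, proves able to move the number a long way: 2,6-dimethylpiperidin-1-yl in place of 3,5-diethylpiperidin-1-yl gives a 23-fold lower number from compound 2 to compound 4 (1.36 log units; beyond the scatter). For the compounds shown here, the earlier compounds offered no pair differing in one place, so this is the first reading of any single change. Going by these compounds alone, the only information available concerns an assay limit and offers no reason for this step. Still open, going by these compounds, is whether the step follows the places of the ring substituents or their change from ethyl to methyl. On these data alone, how a morpholin-4-yl group would read at this place also remains open.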